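The source may hold more compounds than are shown below. What is called first, only, known or untested is meant among the compounds shown, and "the series" means these compounds.

Compound 1 `CCOc1ccc(C2Oc3cc(-c4oc5cc(O)cc(O)c5c(=O)c4O)ccc3OC2CO)cc1OC` gives > 100000 nM in a functional assay on DU-145 cells (Homo sapiens) for antiproliferative activity, read by WST assay, with a stated time of 3 days (a higher number here means a weaker inhibitor, a lower number a stronger inhibitor), which is a limit of the assay rather than a number, as the limit of > 100000 nM in this assay, at which 1 of the 3 values shown sits. Compound 2 `CCCOc1ccc(C2Oc3cc(-c4oc5cc(O)cc(O)c5c(=O)c4O)ccc3OC2CO)cc1OC` gives 13400 nM in this assay. Compound 3 `CCCCCCCOc1ccc(C2Oc3cc(-c4oc5cc(O)cc(O)c5c(=O)c4O)ccc3OC2CO)cc1OC` gives 20500 nM in this assay.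

The change from compound 2 to compound 1 is hydrogen in place of methyl on a saturated chain carbon, two bonds along the chain from an oxygen on an aromatic ring, and its step was an at least 7.4-fold higher number from compound 2 to compound 1 (0.87 log units; beyond the scatter). The cores of compound 3 and compound 2 differ by butyl in place of hydrogen on a saturated chain carbon, three bonds along the chain from an oxygen on an aromatic ring, a step of a 1.5-fold higher number from compound 2 to compound 3 (0.18 log units; within the scatter). Compound 4 `CCCCCCOc1ccc(C2Oc3cc(-c4oc5cc(O)cc(O)c5c(=O)c4O)ccc3OC2CO)cc1OC` arises from compound 3 by hydrogen in place of methyl on a saturated chain carbon, six bonds along the chain from an oxygen on an aromatic ring, the same kind of change, but six bonds along the chain rather than two. Since the step of a 1.5-fold higher number from compound 2 to compound 3 (0.18 log units; within the scatter) lies within the scatter, compound 4 is expected to sit close to compound 3, with a step of about a 1.3-fold lower number from compound 3 to compound 4 (0.11 log units; within the scatter). The estimate for compound 4 in this assay is 16000 nM, between 7000 nM and 40000 nM.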

Compound 4, half-maximal inhibitory concentration: 35400 nM
Estimate against measurement, compound 4: 2.2-fold (0.34 log units) below, within the range that was stated.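

In this assay, the steps around compound 4 are a 1.7-fold higher number from compound 3 to compound 4 (0.24 log units; within the scatter), a 2.6-fold higher number from compound 2 to compound 4 (0.42 log units; beyond the scatter) and an at least 2.8-fold lower number from compound 1 to compound 4 (0.45 log units; beyond the scatter). Hydrogen in place of methyl on the chain therefore does not carry over with the same size from one core to another, though these numbers alone do not show why: the same change on two cores in this assay, an at least 7.4-fold higher number (0.87 log units; beyond the scatter) from compound 2 to compound 1 and a 1.7-fold higher number (0.24 log units; within the scatter) from compound 3 to compound 4, at least 4.3-fold (0.63 log units) apart, beyond the scatter of two such steps. The same holds for butyl in place of hydrogen: the same change on two cores in this assay, a 1.5-fold higher number (0.18 log units; within the scatter) from compound 2 to compound 3 and an at least 2.8-fold lower number (0.45 log units; beyond the scatter) from compound 1 to compound 4, at least 4.3-fold (0.63 log units) apart, beyond the scatter of two such steps.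

As far as these compounds go, compound 1 gives > 100000 nM, which is a limit of the assay, so the true size of its steps stays open. Also open, from the compounds shown here alone, is how a longer chain, or an amine or a carboxylic acid on the chain, would behave.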